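A few compounds are considered here, and "the series" means these few. Any claim that something is new, unique, unknown or untested is made for them only; others in the source may bear on it.

Measured so far in an assay on HeLa cells for inhibition of sphingosine-1-phosphate transporter SPNS2 (Mus musculus), read by LC-MS, tested at 2 uM; on this read-out higher numbers stand for more inhibition at the one concentration tested (going by the name of the read-out) and lower numbers for less inhibition:
- compound 1, `CCCCCCCCCCc1ccc(-c2noc(C3CCNC3)n2)cc1`: 26%
- compound 2, `CCCCCCCCCCc1ccc(-c2noc([C@H]3CCCN3)n2)cc1`: 12%

Within the data shown here, compound 2 stands lowest of the two numbers; its only neighbour is compound 1, and the single measured step, a number 14 percentage points lower from compound 1 to compound 2 (beyond the scatter), separates them. Compound 3, `CCCCCCCCCCc1ccc(-c2noc([C@@H]3CCCN3)n2)cc1`, is the next compound for this assay. It differs from compound 2 as follows: the two compounds have the same atoms and bonds and differ only in configuration as drawn: 1 of 1 stereo elements differ; a stereocentre at a saturated ring carbon is drawn R in compound 2 and S in compound 3. Among the measured compounds shown here, no measured step concerns a change of configuration alone, and the one step available, which exchanges the attachment point of the saturated ring on the aromatic carbon, does not bear on an inversion at a stereocentre. No direction can therefore be read from the series; the expectation in this assay is centred close to compound 2 with a wide range on both sides. Compound 3 is estimated at 18%, with a range of 3% to 40%. The step this estimate implies is a number 6 percentage points higher from compound 2 to compound 3 (within the scatter), expected to be no more than uncertain.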

Compound 3, a percentage reported as inhibition, at one concentration (the size of the read-out at that concentration, not a potency): 21%
For compound 3 the middle estimate is 3 percentage points below the measured one, within the range that was stated.
By their numbers in this assay, from the lowest: compounds 2, 3 and 1 (each within the scatter of the next, the first and the last beyond it).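

In this assay, inversion at the saturated ring carbon gives a number 9 percentage points higher from compound 2 to compound 3 (within the scatter), so the configuration at this position has no readable effect on the numbers. The change of attachment point now reads differently: pyrrolidin-2-yl in place of pyrrolidin-3-yl gives a number 5 percentage points lower from compound 1 to compound 3 (within the scatter) with the S configuration drawn, against a number 14 percentage points lower from compound 1 to compound 2 (beyond the scatter) with the R configuration drawn, so the earlier drop beyond the scatter holds for only one of the two configurations. This pair is the only comparison of configuration alone in the series: the fact that compounds 2 and 3 differ only in the configuration as drawn

The compounds shown leave open whether a primary amine or a carboxylic acid in place of the saturated ring would change the reading in this assay. They also leave open how a longer chain on the shared core would read.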